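The compounds below may be only part of what the source reports. "The series", "measured", "known", "first", "only" and "open" are said of these compounds alone.

Measured so far in an in vitro ADME assay on microsomes from liver (Mus musculus) for pharmacokinetics, read by LC-MS, with a stated time of 10 min, tested at 1 uM; a higher number here means faster removal of the compound, a lower number slower removal:
Compound 1 `CN1C[C@H](C(=O)Nc2ccc(C#N)cc2)[C@@H](c2ccc(/C=C/C(=O)Nc3ccccc3N)cc2)C1`: 35 mL/min/kg
Compound 2 `CC(C)c1ccc(NC(=O)[C@H]2CN(C)C[C@@H]2c2ccc(/C=C/C(=O)Nc3ccccc3N)cc2)cc1`: 54 mL/min/kg

Compound 2 gives the higher of the two numbers, with compound 1 the nearest comparison, but the step of a 1.5-fold higher number from compound 1 to compound 2 (0.19 log units; within the scatter) does not separate the two beyond the scatter of the assay. For the measured compounds named here, that step is the only measured change in this set, and it touches the same aromatic ring on the amide-type nitrogen that is altered in the compound now considered.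

Compound 3 `Cc1cc(NC(=O)[C@H]2CN(C)C[C@@H]2c2ccc(/C=C/C(=O)Nc3ccccc3N)cc2)ccc1F` differs from compound 2 in one place: 4-fluoro-3-methylphenyl in place of 4-isopropylphenyl on an amide-type nitrogen. Going by the values given here, the one measured step on this ring, a 1.5-fold higher number from compound 1 to compound 2 (0.19 log units; within the scatter), bears directly on this change and was small. Among the compounds with values here, with no other steps to draw on, the account expects no movement beyond the scatter in this assay from compound 2 to compound 3, and the expected step is a 1.2-fold lower number from compound 2 to compound 3 (0.08 log units; within the scatter). For compound 3 the estimate in this assay is therefore 45 mL/min/kg, with a range from 22 mL/min/kg to 90 mL/min/kg.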

Compound 3, clearance: 62 mL/min/kg
For compound 3 the middle estimate is 1.4-fold (0.14 log units) below the measured one; the measured number falls inside the stated range.
By their numbers in this assay, from the lowest: compounds 1, 2 and 3 (each within the scatter of the next).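

In this assay, 4-fluoro-3-methylphenyl in place of 4-isopropylphenyl on the amide-type nitrogen gives a 1.1-fold higher number from compound 2 to compound 3 (0.06 log units; within the scatter), and the same group in place of 4-cyanophenyl gives a 1.8-fold higher number from compound 1 to compound 3 (0.25 log units; within the scatter). For the compounds shown here, the earlier compounds offered only one exchange at this position, whereas these steps add a third aryl group, one carrying fluorine and methyl, and every step among compound 1, compound 2 and compound 3 now lies within the scatter, so this assay does not separate the three groups from one another and none of the three compounds goes against that reading. Nothing available bears on why the three numbers lie so close together.

All three groups at this position are substituted phenyl rings, so it remains open whether a saturated group such as cyclohexyl, a pyridine ring, or a phenyl ring carrying a carboxylic acid or an amine would also stay within the scatter of these compounds. It is also open whether the numbers would move in this assay with a change elsewhere on the shared core, since every step shown falls at this one position.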